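Chloro for Bromo on a Para-Substituted Phenyl Ring

The compounds below may be only part of what the source reports. "The series", "measured", "known", "first", "only" and "open" are said of these compounds alone.

Compound 1 `C=C1C[C@]23C[C@@]1(O)CC[C@@H]2c1cccc(C)c1[C@@H]3Cn1cc(-c2ccc(Br)cc2)nn1` — cytotoxicity: > 20000 nM (a limit of the assay)
Compound 2 `C=C1C[C@]23C[C@@]1(O)CC[C@H]2c1ccc(OS(=O)(=O)c2ccc(C)cc2)c(C)c1[C@@H]3Cn1cc(-c2ccc(C)cc2)nn1` — cytotoxicity: > 20000 nM (a limit of the assay)
Compound 3 `C=C1C[C@]23C[C@@]1(O)CC[C@H]2c1cc(Br)c(O)c(C)c1[C@@H]3Cn1cc(-c2ccc(Cl)cc2)nn1` — cytotoxicity: 18000 nM

The three measured compounds were tested in a functional assay on SW480 cells (Homo sapiens) for cytotoxicity, read by MTT assay, with a stated time of 4 days; on this read-out lower numbers stand for stronger inhibition and higher numbers for weaker inhibition. Compound 1 gives only a limit there, > 20000 nM. Compound 2 likewise gives only a limit, > 20000 nM. Compound 3 gives a number, 18000 nM. Among the measured compounds shown here, compound 1 thus stands at the limit of > 20000 nM in this assay, at which 2 of the 3 values shown sit, and no measured step to another compound is known for it.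

Compound 4 `C=C1C[C@]23C[C@@]1(O)CC[C@@H]2c1cccc(C)c1[C@@H]3Cn1cc(-c2ccc(Cl)cc2)nn1` differs from compound 1 by chloro in place of bromo on an aromatic carbon. For the measured compounds named here, no pair of measured compounds isolates this change, so the step in this assay cannot be read from the data. Given that compound 1 sits at the limit of > 20000 nM in this assay, at which 2 of the 3 values shown sit, the step from compound 1 to compound 4 is expected to be small and to remain within the scatter, a step that the limit leaves unreadable from compound 1 to compound 4. Compound 4 is therefore expected to give about 25000 nM, between 12000 nM and 60000 nM, most likely reported again as a limit.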

Compound 4, half-maximal inhibitory concentration: > 20000 nM
Compound 4: a limit, no number; the forecaster's own chance of this, stated with the estimate: 70%; the middle value lies beyond the limit too.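

Among the compounds shown here, compound 1 and compound 4 each give only a limit in this assay, so no step from bromo to chloro can be read between them: the limit of > 20000 nM in this assay, at which 3 of the 4 values shown sit. The compounds shown leave open whether chloro in place of bromo on an aromatic carbon shifts cytotoxicity at all in this assay.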